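Methyl for fluoro on the fused ring of compound 1

The source may report more compounds than this note shows. Statements on the series, on what has been measured and on what is new or still open speak of the compounds shown alone.

Of the compounds shown here, three have so far been measured in a functional assay on cells for agonist activity at Free fatty acid receptor 1 (Homo sapiens), read by FLIPR and calcium flux; on this read-out lower numbers stand for an effect already at smaller amounts and higher numbers for an effect only at larger amounts of compound. Compound 1 `CC#C[C@@H](Cc1nnn[nH]1)c1ccc(OCc2ccc3sc(F)c(-c4ccccc4C)c3c2)cc1` gives 15 nM, the second highest of the three numbers. Compound 2 `CC#C[C@@H](Cc1nnn[nH]1)c1ccc(OCc2ccc3scc(-c4ccc(OCCCS(C)(=O)=O)cc4C)c3c2)cc1` gives 12 nM, which sits within the scatter of compound 1. Compound 3 `CC#C[C@@H](Cc1nnn[nH]1)c1ccc(OCc2ccc3scc(-c4cncnc4C)c3c2)cc1` gives 37 nM, a higher number that lies beyond the scatter of compound 1. Compound 4 `CC#C[C@@H](Cc1nnn[nH]1)c1ccc(OCc2ccc3sc(C)c(-c4ccccc4C)c3c2)cc1` has not been measured; it differs from compound 1 by methyl in place of fluoro on an aromatic carbon. Within the data shown here, no measured pair in this set carries the same exchange, so there is no observed step to lean on. No step beyond the scatter is expected in this assay. Compound 4 is estimated at 15 nM, with a range from 6 nM to 40 nM. The expected step of no change at the digits printed from compound 1 to compound 4 (within the scatter) is small in either direction.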

Compound 4, half-maximal effective concentration: 20 nM
Compound 4: middle estimate off by 1.3-fold (0.12 log units), on the low side; the range from low to high includes it.
By their numbers in this assay, from the lowest: compounds 2, 1, 4 and 3 (each within the scatter of the next, the first and the last beyond it).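

Methyl in place of fluoro on the aromatic carbon next to the ring sulfur gives the first one-place step in the series (a 1.3-fold higher number from compound 1 to compound 4 (0.12 log units; within the scatter)). With the 2-methylphenyl group kept, these two substituents cannot be told apart at this position in this assay, so the exchange of one heavy atom for another leaves the reading within the scatter. Nothing available explains this result.

Still open, on these data alone, is whether an amine, a carboxylic acid or a longer alkyl chain on this carbon would stay in the same range. Also open, as far as these compounds go, is whether methyl here would read the same alongside the aryl groups of compound 2 and compound 3.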